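Swapping pyridin-4-yl for 4-fluorophenyl in a sulfamate series

The source may report more compounds than this note shows. Statements on the series, on what has been measured and on what is new or still open speak of the compounds shown alone.

Compound 1, `CCN(Cc1ccccc1)c1cccc(C(=O)N2CCc3ccc(OS(N)(=O)=O)cc3C2)c1`: 17.3%
Compound 2, `CCN(Cc1ccncc1)c1cccc(C(=O)N2CCc3ccc(OS(N)(=O)=O)cc3C2)c1`: 33.3%

In an assay on HEK293 cells for inhibition of Steryl-sulfatase (Homo sapiens), tested at 0.1 uM (on this read-out lower numbers stand for a weaker effect and higher numbers for a stronger effect at the one concentration tested), compound 2 gives 33.3%, the higher of the two measured numbers, while compound 1 gives 17.3%. Compound 3, `CCN(Cc1ccc(F)cc1)c1cccc(C(=O)N2CCc3ccc(OS(N)(=O)=O)cc3C2)c1`, differs from compound 2 in one place: 4-fluorophenyl in place of pyridin-4-yl on a saturated chain carbon bound to a nitrogen on an aromatic ring. Among the measured compounds shown here, the only step that bears on this is a number 16 percentage points higher from compound 1 to compound 2 (beyond the scatter), where introducing pyridin-4-yl in place of phenyl raised the number. Compound 3 removes pyridin-4-yl again, so a modest move back toward the value of compound 1 is expected, a number 13.3 percentage points lower from compound 2 to compound 3 (beyond the scatter). Compound 3 is therefore estimated at 20%, with a range from 8% to 34%.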

Compound 3, a percentage reported as inhibition, at one concentration (the size of the read-out at that concentration, not a potency): 10.9%
The estimate for compound 3 lay 9.1 percentage points above the measured number; low and high end bracket the measured number.
By their numbers in this assay, from the lowest: compounds 3 and 1 (each within the scatter of the next); then compound 2.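

In this assay the exchange of pyridin-4-yl for 4-fluorophenyl gives a number 22.4 percentage points lower from compound 2 to compound 3 (beyond the scatter) and so, among these three compounds, the higher number stays with the pyridin-4-yl of compound 2. Fluoro in place of hydrogen on an aromatic carbon gives a number 6.4 percentage points lower from compound 1 to compound 3 (within the scatter) and so does not set the two carbon-only rings apart. Nothing measured here accounts for the difference between pyridin-4-yl and these two rings. As far as these compounds go, whether pyridin-3-yl or pyridin-2-yl on this saturated chain carbon would keep the higher number remains open, as does the effect of a carboxylic acid there.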